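A few compounds are considered here, and "the series" means these few. Any claim that something is new, unique, unknown or untested is made for them only; others in the source may bear on it.

Compound 2 `CC(C)(O)c1cn(-c2ccc(-c3cccc(S(C)(=O)=O)c3)cc2)c(C(C)(C)c2ccccc2Cl)n1` gives 99.9% in an ADME assay on isolated protein for binding affinity to Alpha-1-acid glycoprotein 1 (Homo sapiens), using equilibrium dialysis, with a stated time of 4 h, tested at 1 uM, the lowest unbound fraction among the three measured compounds. Among the measured compounds shown here, compound 1 `CC(C)(O)c1cn(-c2ccc(-c3ccc(CO)c(S(C)(=O)=O)c3)cc2)c(C(C)(C)c2ccccc2Cl)n1` gives 90.2% in this assay, and the one measured single-point step, a 98-fold lower unbound fraction from compound 1 to compound 2 (1.99 log units; beyond the scatter), is the only change that has been weighed on its own. Compound 3 `CC(C)(O)c1cn(-c2ccc(-c3cc(F)c(CO)c(S(C)(=O)=O)c3)cc2)c(C(C)(C)c2cccc(F)c2Cl)n1` gives 87.6% in this assay; its value and that of compound 1 lie close to each other, whereas compound 2 stands far from both.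

Compound 4 `CC(C)(O)c1cn(-c2ccc(-c3cccc(S(C)(=O)=O)c3)cc2)c(C(C)(C)c2c(Cl)cccc2Cl)n1` differs from compound 2 by chloro in place of hydrogen on an aromatic carbon. For the measured compounds named here, no measured step touches this position, so the step from compound 1 to compound 2 bears on it only as a sign of how strongly this series can answer a change of one group elsewhere, and the pair compound 1 and compound 3 concerns different positions altogether. The analyst therefore expects in this assay at most a modest shift toward more binding, estimated as a 2.0-fold lower unbound fraction from compound 2 to compound 4 (0.30 log units; within the scatter). Compound 4 is estimated at 99.95%, with a range from 99.7% to 99.99%.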

Compound 4, plasma protein binding: 99%
Estimate against measurement, compound 4: 20-fold (1.30 log units) (unbound fraction) below; measured number below the stated range.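

In this assay the change from 2-chlorophenyl to 2,6-dichlorophenyl gives a 10-fold higher unbound fraction from compound 2 to compound 4 (1.00 log units; beyond the scatter), so chloro at this aromatic carbon, ortho to a large group, moves the read-out toward more free compound. This is the first single change shown on this ring alone, and it shows that the ring can shift binding beyond the scatter with the methylsulfonyl-bearing ring left unchanged. The compounds shown offer no measurement that explains the direction of this step.

Going by these compounds, whether chloro at this place would have a like effect on a compound carrying the hydroxymethyl group of compound 1 remains open. So does the outcome with another group at this aromatic carbon, such as methoxy, a nitrile or an amine.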